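Swapping Carbonyl for Sulfonyl on the Ring Nitrogen

The source may report more compounds than this note shows. Statements on the series, on what has been measured and on what is new or still open speak of the compounds shown alone.

Compound 1 `CN1CCN(c2ccc(C3=NN(C(=O)c4ccc(C(F)(F)F)cc4)C(c4ccc(N(C)C)cc4)C3)cc2)CC1` and compound 2 `CN(C)c1ccc(C2CC(c3ccc(-n4cncn4)cc3)=NN2C(=O)c2ccc(C(F)(F)F)cc2)cc1` share a core and were both tested in a functional assay on HCC1806 cells (Homo sapiens) for inhibition, read by sulforhodamine B assay, tested at 10 uM; a higher number here means more inhibition at the concentration tested (going by the name of the read-out), a lower number less inhibition. Compound 1 gives 84.1%, while compound 2 gives 7%, the lower of the two numbers shown, and the step between them is a number 77.1 percentage points lower from compound 1 to compound 2 (beyond the scatter). Compound 3 `CN(C)c1ccc(C2CC(c3ccc(-n4cncn4)cc3)=NN2S(=O)(=O)c2ccc(C#N)cc2)cc1` differs from compound 2 in a different place: (4-cyanophenyl)sulfonyl in place of (4-(trifluoromethyl)phenyl)carbonyl on an amine nitrogen in a ring. Within the data shown here, the only measured step concerns the group on the aromatic carbon, not the group on the amine nitrogen in the ring, so no measured step bears on this change, and the data give no direction for it. With nothing pointing up or down, the expected step is a number 8 percentage points higher from compound 2 to compound 3 (within the scatter), within the scatter, though the range is kept wide. The estimate for compound 3 in this assay is 15%, between 0% and 55%.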

Compound 3, a percentage reported as inhibition, at one concentration (the size of the read-out at that concentration, not a potency): 33.1%
Compound 3: the middle estimate sits 18.1 percentage points below what was measured; the measured number falls inside the stated range.
By their numbers in this assay, from the lowest: compound 2; then compound 3; then compound 1.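

In this assay, the step is a number 26.1 percentage points higher from compound 2 to compound 3 (beyond the scatter) when (4-cyanophenyl)sulfonyl replaces (4-(trifluoromethyl)phenyl)carbonyl on the amine nitrogen in the ring. Among these compounds, this is the first sign that the group on this nitrogen, and not only the group on the aromatic carbon changed earlier, can shift the inhibition, and that this nitrogen can carry a sulfonyl link and still give a measurable reading. No supporting measurement is available to explain the rise.

This swap changes both the carbonyl link and the ring substituent, so the shares of sulfonyl and nitrile cannot be separated, and a (4-(trifluoromethyl)phenyl)sulfonyl group would split them. As far as these compounds go, it also remains open whether the same swap would act alike with 4-methylpiperazin-1-yl on the aromatic carbon, or how a small acetyl group would fare on this nitrogen.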